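Swapping a Fluorophenyl Amine Substituent for an Aminophenyl

This account rests on a few compounds, and the source may have more. Where it says the series, first, only, none or still open, it means among the compounds named here.

Measured so far:
compound 1, `Fc1ccc(Nc2nc(-c3cccc(F)c3)nc3ccc(F)cc23)cc1`: > 50000 nM
compound 2, `Fc1cccc(Nc2nc(-c3cccc(F)c3)nc3ccc(F)cc23)c1`: 42300 nM
compound 3, `Fc1cccc(-c2nc(Nc3ccc(Cl)cc3)c3cc(F)ccc3n2)c1`: 32700 nM

In a functional assay on U-937 cells (Homo sapiens) for cytotoxicity, read by MTT assay, with a stated time of 48 h (on this read-out higher numbers stand for weaker inhibition and lower numbers for stronger inhibition), compound 1 reaches only the limit of the assay, > 50000 nM, rather than a number. Compound 2 gives 42300 nM in this assay, the higher of the two actual numbers; its nearest neighbour is compound 3 at 32700 nM, and the gap, a 1.3-fold lower number from compound 2 to compound 3 (0.11 log units; within the scatter), stays within the scatter. Compound 1 sits at a limit, (the limit of > 50000 nM in this assay, at which 1 of the 3 values shown sits).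

The unmeasured compound 4, `Nc1ccc(Nc2nc(-c3cccc(F)c3)nc3ccc(F)cc23)cc1`, differs from compound 2 in one place: 4-aminophenyl in place of 3-fluorophenyl on a nitrogen on an aromatic ring.

Two measured steps change the aryl group on the same nitrogen: an at least 1.1-fold lower number from compound 1 to compound 2 (0.07 log units; that floor lies within the scatter) and a 1.3-fold lower number from compound 2 to compound 3 (0.11 log units; within the scatter). Both are small. The third, an at least 1.5-fold lower number from compound 1 to compound 3 (0.18 log units; that floor lies within the scatter), exchanges one halogen for another and is also small. Going by the values given here, none of these steps replaces a fluoro with an amino group, so there is no direct precedent for that part of the change, and all three point to a flat series. Given the small measured steps, compound 4 is expected to show a 1.1-fold lower number from compound 2 to compound 4 (0.02 log units; within the scatter), lying within the scatter. The value expected for compound 4 is 40000 nM, with a range from 15000 nM to 80000 nM. For compound 4 there is a real chance that only a limit is reported.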

Compound 4, half-maximal inhibitory concentration: > 50000 nM
Compound 4: no number, only a limit; the forecaster's own chance of this, stated with the estimate: 35%; middle value at least 1.2-fold (0.09 log units) from the limit.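

In this assay compound 4, the first here to carry 4-aminophenyl on the nitrogen, reaches only a limit, > 50000 nM, and not a number: the limit of > 50000 nM in this assay, at which 2 of the 4 values shown sit.

From the compounds shown here alone, two steps can be read, an at least 1.1-fold higher number from compound 2 to compound 4 (0.07 log units; that floor lies within the scatter) and an at least 1.5-fold higher number from compound 3 to compound 4 (0.18 log units; that floor lies within the scatter), and although their true sizes remain unknown, neither gives any sign that the amino group brings stronger inhibition than the halogens of compound 2 and compound 3. The step between compound 1 and compound 4 cannot be read, so across fluoro, chloro and amino groups on this aryl ring, no readable step lies beyond the scatter.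

The compounds shown leave open whether a hydroxyl group or a carboxylic acid in place of the amino group would bring a clear change in this cell read-out. They also do not tell what actual number lies behind the limit of compound 4, so the full size of the change from a halogen to an amino group stays unknown.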